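Benzothiazolylamine chain series: from compound 2 to compound 3

The source may hold more compounds than are shown below. What is called first, only, known or untested is meant among the compounds shown, and "the series" means these compounds.

Of the compounds shown here, two have been measured so far, both sharing the same core with a chain ending in an amine nitrogen bound to a benzothiazole. In a functional assay on SK-OV-3 cells (Homo sapiens) for cytotoxicity, read by sulforhodamine B assay, with a stated time of 48 h (on this read-out higher numbers stand for weaker inhibition and lower numbers for stronger inhibition), compound 1 `O=c1cc(-c2ccccc2)oc2cc(OCCCCNc3nc4ccc(Cl)cc4s3)cc(O)c12` gives 39.3 ug/mL. Compound 2 `O=c1cc(-c2ccccc2)oc2cc(OCCCCNc3nc4ccc(Br)cc4s3)cc(O)c12` gives 35.1 ug/mL in this assay. For the measured compounds named here, the one measured step, a 1.1-fold lower number from compound 1 to compound 2 (0.05 log units; within the scatter), lies within the scatter, so compound 2 and compound 1 cannot be told apart on these numbers; compound 2 sits at one end of the pair, with compound 1 as its only neighbour and that neighbour within the scatter.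

Compound 3 `O=c1cc(-c2ccccc2)oc2cc(OCCCCNNc3nc4ccccc4s3)cc(O)c12` differs from compound 2 by (1,3-benzothiazol-2-yl)amino in place of 6-bromo-1,3-benzothiazol-2-yl on an amine nitrogen. Going by the values given here, no measured step bears directly on this change: the only step in hand swaps one halogen for another on the benzothiazole, whereas the entering group carries no halogen at all and adds a second nitrogen to the link. With nothing to anchor a direction, the expected step from compound 2 to compound 3 in this assay is none beyond the scatter, a 1.1-fold higher number from compound 2 to compound 3 (0.06 log units; within the scatter), though the uncertainty is wide. Compound 3 is therefore estimated at 40 ug/mL, with a range from 15 ug/mL to 110 ug/mL.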

Compound 3, half-maximal inhibitory concentration: 51.7 ug/mL
For compound 3 the middle estimate is 1.3-fold (0.11 log units) below the measured one, and the stated range covers the measured number.
By their numbers in this assay, from the lowest: compounds 2, 1 and 3 (each within the scatter of the next).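

In this assay, (1,3-benzothiazol-2-yl)amino in place of 6-bromo-1,3-benzothiazol-2-yl on the amine nitrogen gives a 1.5-fold higher number from compound 2 to compound 3 (0.17 log units; within the scatter), and the same replacement of 6-chloro-1,3-benzothiazol-2-yl gives a 1.3-fold higher number from compound 1 to compound 3 (0.12 log units; within the scatter). The amine nitrogen bound to a saturated chain carbon therefore accepts a change larger than the halogen swap, with the halogen gone and a further nitrogen, hydrogen-bond donor and hydrogen-bond acceptor added, without the three compounds separating beyond the scatter. No measurement in hand accounts for these numbers.

The loss of the halogen and the added nitrogen arrive together here, so their separate contributions remain unresolved; a plain 1,3-benzothiazol-2-yl on the amine nitrogen and a (6-bromo-1,3-benzothiazol-2-yl)amino group would each isolate one of the two. Also open, from the compounds shown here alone, is whether a clear difference in this assay would appear with a non-halogen group such as 6-methoxy-1,3-benzothiazol-2-yl, with an amide in place of the amine link, or with a longer chain.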